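This account rests on a few compounds, and the source may have more. Where it says the series, first, only, none or still open, it means among the compounds named here.

Compound 1 `CNC(=O)C[C@@H]1C[C@@H](c2ccc(Cl)c(Cl)c2)[C@H](NC(=O)c2cc(-c3c(Cl)cnn3C)c(Cl)o2)CN1` gives 40 nM in a functional assay on LNCaP cells (Homo sapiens) for antiproliferative activity; a higher number here means a weaker inhibitor, a lower number a stronger inhibitor. Compound 2 `Cn1ncc(Cl)c1-c1cc(C(=O)N[C@@H]2CN[C@H](CC(O)CO)C[C@H]2c2ccc(Cl)c(Cl)c2)oc1Cl` gives 70 nM in this assay, and the step of a 1.8-fold higher number from compound 1 to compound 2 (0.24 log units; within the scatter) is within the scatter. Compound 3 `Cn1ncc(Cl)c1-c1cc(C(=O)N[C@@H]2CN[C@H](CCN3CCCCC3)C[C@H]2c2ccc(Cl)c(Cl)c2)oc1Cl` gives 1780 nM in this assay; the steps of a 45-fold higher number from compound 1 to compound 3 (1.65 log units; beyond the scatter) and a 25-fold higher number from compound 2 to compound 3 (1.41 log units; beyond the scatter) are both large and beyond the scatter. Compound 3 therefore stands at the highest number of the three measured compounds, separated from compound 2 and from compound 1 beyond the scatter.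

Compound 4 `CN(C)CC[C@@H]1C[C@@H](c2ccc(Cl)c(Cl)c2)[C@H](NC(=O)c2cc(-c3c(Cl)cnn3C)c(Cl)o2)CN1` differs from compound 3 in one place: dimethylamino in place of piperidin-1-yl on a saturated chain carbon, two bonds along the chain from a saturated ring carbon. Among the measured compounds shown here, no measured step alters this position in the same way. The two steps reaching compound 3 show only that the chain carrying piperidin-1-yl sits far above the methylcarbamoyl and 1,2-dihydroxyethyl chains; they do not tell whether dimethylamino behaves like piperidin-1-yl or recovers part of that distance. The expectation is a number near compound 3, with at most a modest lowering, so a 1.8-fold lower number from compound 3 to compound 4 (0.25 log units; within the scatter) is expected. Compound 4 is estimated at 1000 nM, with a range from 300 nM to 3500 nM.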

Compound 4, half-maximal inhibitory concentration: 1930 nM
Estimate against measurement, compound 4: 1.9-fold (0.29 log units) below, within the range that was stated.
By their numbers in this assay, from the lowest: compounds 1 and 2 (each within the scatter of the next); then compounds 3 and 4 (each within the scatter of the next).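

In this assay, dimethylamino in place of piperidin-1-yl gives a 1.1-fold higher number from compound 3 to compound 4 (0.04 log units; within the scatter) and so the ring is not required for the high number: going from 6 heavy atoms to 3 at this position leaves the two compounds within the scatter of each other. The large distance from the neutral chains also holds for the smaller amine, with a 28-fold higher number from compound 2 to compound 4 (1.44 log units; beyond the scatter) and a 48-fold higher number from compound 1 to compound 4 (1.68 log units; beyond the scatter) both large, so among the compounds shown both chains ending in a tertiary amine stand far above the methylcarbamoyl and 1,2-dihydroxyethyl chains. No measurement here explains that distance.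

As far as these compounds go, whether a primary amine, a morpholin-4-yl group or a carboxylic acid at the end of this chain would fall with compounds 1 and 2 or with compounds 3 and 4 remains open. Also open, from the compounds shown here alone, is whether a longer chain carrying dimethylamino would keep the number of compound 4.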